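This account rests on a few compounds, and the source may have more. Where it says the series, first, only, none or still open, it means among the compounds named here.

Measured so far in a functional assay for inhibition of Polyunsaturated fatty acid 5-lipoxygenase (Homo sapiens), in the absence of a further agent; on this read-out lower numbers stand for stronger inhibition and higher numbers for weaker inhibition:
compound 1 `COc1ccc(Cc2oc3c(Cl)cc(Cl)c(O)c3c2C)cc1`: 860 nM
compound 2 `COc1ccc(Cc2oc3c(Cl)cc(C(C)(C)C)c(O)c3c2C)cc1`: 99 nM
compound 3 `COc1ccc(Cc2oc3c(Cl)ccc(O)c3c2C)cc1`: 376 nM

Compound 1 carries the highest number of the three; compound 3 stands nearest to it and compound 2 furthest. Compound 4 `COc1ccc(Cc2oc3c(Cl)cc(CCC(=O)O)c(O)c3c2C)cc1` has not yet been measured in this assay. It differs from compound 1 by 2-carboxyethyl in place of chloro on an aromatic carbon. Two measured steps replace the chloro at this same carbon: an 8.7-fold lower number from compound 1 to compound 2 (0.94 log units; beyond the scatter) and a 2.3-fold lower number from compound 1 to compound 3 (0.36 log units; beyond the scatter). Both moved toward lower numbers. Neither of those entering groups resembles 2-carboxyethyl, so the size of the step is uncertain, but a lower number than for compound 1 is expected. The estimate for compound 4 is 320 nM, expected to fall between 110 nM and 950 nM, which corresponds to an expected step of a 2.7-fold lower number from compound 1 to compound 4 (0.43 log units; beyond the scatter).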

Compound 4, half-maximal inhibitory concentration: 2130 nM
Beside the measured number, compound 4's estimate is 6.7-fold (0.82 log units) below it; measured number outside the range, above it.
By their numbers in this assay, from the lowest: compound 2; then compound 3; then compound 1; then compound 4.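

Among the compounds shown here, at this carbon, ortho to a hydroxy group, replacing the chloro does not always lower the number: 2-carboxyethyl gives a 2.5-fold higher number from compound 1 to compound 4 (0.39 log units; beyond the scatter), the only step from compound 1 that goes upward. The same group gives a 5.7-fold higher number from compound 3 to compound 4 (0.75 log units; beyond the scatter) against hydrogen and a 22-fold higher number from compound 2 to compound 4 (1.33 log units; beyond the scatter) against tert-butyl, so the entering group sets the direction of the step here as well as its size. No measurement given here bears on the cause of this reversal.

From the compounds shown here alone, it remains open whether the rise follows the terminal acid or the chain itself. A plain propyl chain or the methyl ester of the acid would separate the two.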